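Exchanging the benzylic substituent on a shared purine-like core

A few compounds are considered here, and "the series" means these few. Any claim that something is new, unique, unknown or untested is made for them only; others in the source may bear on it.

Measured compounds:
Compound 1 `Nc1nc(O)c2c(n1)n(C1OC(CO)[C@@H](O)[C@H]1O)c(=O)n2Cc1ccc(Cl)c(Cl)c1`: 55%
Compound 2 `C=CCn1c(=O)n([C@@H]2O[C@H](CO)[C@H]3OC(C)(CCC(=O)NC)O[C@H]32)c2nc(N)nc(O)c21`: 9%
Compound 3 `C=CCn1c(=O)n([C@H]2CO[C@@H](CO)C2)c2nc(N)nc(O)c21`: 10%

In a functional assay on the whole organism (B cells) with Mus musculus as the target (on this read-out lower numbers stand for smaller maximal responses and higher numbers for larger maximal responses), compound 1 gives 55%, the highest of the three numbers. Compound 3 stands nearest to it with 10%, a gap that lies beyond the usual scatter of this assay. Compound 2 is furthest with 9%; its distance from compound 1 is also beyond the scatter, while compounds 2 and 3 themselves lie within the scatter of each other, so no order is claimed between them. Among the measured compounds shown here, no step between two measured compounds that differ in a single place is available, so the values of compounds 2 and 3 speak only for themselves.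

Compound 4 `Nc1nc(O)c2c(n1)n(C1OC(CO)[C@@H](O)[C@H]1O)c(=O)n2CC(O)CSc1ccccc1` has not yet been measured in this assay. It differs from compound 1 as follows: 1-hydroxy-2-(phenylsulfanyl)ethyl in place of 3,4-dichlorophenyl on a saturated chain carbon bound to an aromatic nitrogen. For the measured compounds named here, with no single-point step on record, the expectation for compound 4 rests on compound 1 alone. Compound 4 is expected to give 38%, in a range from 15% to 65%. The estimated step of a number 17 percentage points lower from compound 1 to compound 4 (beyond the scatter) is expected to be a moderate decrease, somewhat beyond the scatter.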

Compound 4, largest response reached (reported as maximal response), in percent of the reference or control that the assay uses: 12%
Compound 4: middle estimate off by 26 percentage points, on the high side; measured number outside the range, below it.
By their numbers in this assay, from the lowest: compounds 2, 3 and 4 (each within the scatter of the next); then compound 1.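

In this assay, among the compounds shown here, the exchange on a saturated chain carbon bound to an aromatic nitrogen gives the first single-place step on record, a number 43 percentage points lower from compound 1 to compound 4 (beyond the scatter), which shows that the maximal response depends strongly on what this position carries. 3,4-Dichlorophenyl and 1-hydroxy-2-(phenylsulfanyl)ethyl each hold one six-membered aromatic ring of carbon only, so the presence of such a ring in the substituent is not enough to retain the larger response of compound 1. No measurement at hand bears on why the number falls.

The step changes several things at once, as the two chlorine atoms leave while the oxygen, the sulfur and a longer link to the ring enter, so the loss cannot be assigned to any one of them. The compounds shown leave open whether an unsubstituted phenyl or a 4-chlorophenyl would keep the response of compound 1, and whether a 1-hydroxy-2-phenoxyethyl, with oxygen in place of sulfur, would behave like the group in compound 4.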